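The source may hold more compounds than are shown below. What is called first, only, known or untested is meant among the compounds shown, and "the series" means these compounds.

In a functional assay on HT-1080 cells (Homo sapiens) for cytotoxicity, read by MTT assay, with a stated time of 72 h (a lower number here means a stronger inhibitor, a higher number a weaker inhibitor), compound 1 (`COc1ccc(/C=C2\CCC/C(=C\c3cccc(OC)c3OC)C2=O)cc1OC`) gives 6400 nM, compound 2 (`COc1cccc(/C=C2\CCC/C(=C\c3ccc(OC)c(OC)c3)C2=O)c1`) gives 4600 nM and compound 3 (`COc1cc(/C=C2\CCC/C(=C\c3ccc(OC)c(OC)c3)C2=O)cc(OC)c1`) gives 2600 nM. Compound 2 holds the middle number of the three. The measured steps touching it are a 1.4-fold lower number from compound 1 to compound 2 (0.14 log units; within the scatter), with hydrogen in place of methoxy on an aromatic carbon, and a 1.8-fold lower number from compound 2 to compound 3 (0.25 log units; within the scatter), with methoxy in place of hydrogen on an aromatic carbon. Compound 4 (`COc1ccc(/C=C2\CCC/C(=C\c3ccc(O)c(Cl)c3)C2=O)cc1OC`) has 3-chloro-4-hydroxyphenyl in place of 3-methoxyphenyl on a double-bonded chain carbon bound to a double-bonded ring carbon. Neither measured step covers a hydroxy or chlorine substituent, so they offer only a guide to size, and no step beyond the scatter is expected in this assay. The expected change is a 1.5-fold lower number from compound 2 to compound 4 (0.19 log units; within the scatter). For compound 4 the estimate is 3000 nM, with an expected range of 800 nM to 8000 nM.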

Compound 4, half-maximal inhibitory concentration: 7600 nM
Compound 4: middle estimate off by 2.5-fold (0.40 log units), on the low side; the range from low to high includes it.
By their numbers in this assay, from the lowest: compounds 3, 2, 1 and 4 (each within the scatter of the next, the first and the last beyond it).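

Exchanging 3-methoxyphenyl for 3-chloro-4-hydroxyphenyl on a double-bonded chain carbon bound to a double-bonded ring carbon gives a 1.7-fold higher number from compound 2 to compound 4 (0.22 log units; within the scatter). The earlier steps shown here swapped only methoxy and hydrogen, whereas this one brings in hydroxy and chlorine together, and the result still stays within the scatter of compound 2. Nothing available explains this result.

The compounds shown do not separate the hydroxy contribution from the chlorine contribution. On these data alone, how an amine or a carboxylic acid on that phenyl ring would read also stays open.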